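The compounds below may be only part of what the source reports. "The series", "measured", "known", "first", "only" and "open" are said of these compounds alone.

Compound 1 `N#Cc1cc(F)cc(C(=O)Nc2ccc(F)cc2)c1` and compound 2 `Cc1ccc(NC(=O)c2cc(F)cc(C#N)c2)cc1` share one core and differ in a single group on an aromatic carbon. In an in vitro functional assay on HEK293-A cells for antagonist activity at metabotropic glutamate receptor 5 (Rattus norvegicus), read by calcium flux (on this read-out lower numbers stand for stronger inhibition and higher numbers for weaker inhibition), compound 1 gives only a limit, > 10000 nM. In this assay compound 2 likewise gives only a limit, > 30000 nM. The step that the two limits leave unreadable from compound 1 to compound 2, methyl in place of fluoro on an aromatic carbon, has no readable size, since one end sits at the limit of > 10000 nM in this assay, at which 1 of the 2 values shown sits, and the other at the limit of > 30000 nM in this assay, at which 1 of the 2 values shown sits. Compound 3 `COc1ccc(NC(=O)c2cc(F)cc(C#N)c2)cc1` carries the change (methoxy in place of methyl on an aromatic carbon). For the measured compounds named here, no measured step involves a methoxy, and the one measured step cannot be read, so there is no basis for expecting a shift beyond the scatter. Compound 2 stands at a limit, and the step of a number no higher from compound 2 to compound 3 (the limit leaves the size open) is expected to be small. The estimate for compound 3 in this assay is 30000 nM, with a range from 10000 nM to 100000 nM.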

Compound 3, half-maximal inhibitory concentration: > 30000 nM
Compound 3 ended at the assay's limit; the forecaster's own chance of this, stated with the estimate: 80%; the middle value lies on the limit itself.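

Compound 3 gives only a limit in this assay and so do compound 1 and compound 2, so none of the steps among these three compounds can be read: the limit of > 30000 nM in this assay, at which 2 of the 3 values shown sit.

The compounds shown leave open how fluoro, methyl and methoxy rank on this aromatic carbon, and whether any of them gives a readable inhibition.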